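Thiocarbamate series: methylpiperidine in place of morpholine

The source may hold more compounds than are shown below. What is called first, only, known or untested is meant among the compounds shown, and "the series" means these compounds.

Among the compounds with values here, compound 2 `Cc1ncc([N+](=O)[O-])n1CC(O)CSC(=S)N1CCOCC1` gives 4520000 nM in a toxicity assay on HeLa cells (Homo sapiens) for cytotoxicity, read by MTT assay, with a stated time of 24 h (a higher number here means a weaker inhibitor, a lower number a stronger inhibitor), the higher of the two numbers measured so far. Compound 1 `Cc1ncc([N+](=O)[O-])n1CC(O)CSC(=S)N1CCN(c2cccc(Cl)c2)CC1` gives 1080000 nM in this assay, and the gap between the two compounds lies beyond the usual scatter. Compound 3 `Cc1ncc([N+](=O)[O-])n1CC(O)CSC(=S)N1CCCC(C)C1` differs from compound 2 by 3-methylpiperidin-1-yl in place of morpholin-4-yl on a thiocarbonyl carbon. Within the data shown here, no measured step covers this change. The shift is expected to be small and toward a lower number, estimated as a 1.8-fold lower number from compound 2 to compound 3 (0.26 log units; within the scatter). Compound 3 is expected to give about 2500000 nM in this assay, within a range from 1000000 nM to 6000000 nM.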

Compound 3, half-maximal inhibitory concentration: 609000 nM
Compound 3: the middle estimate sits 4.1-fold (0.61 log units) above what was measured; measured number below the stated range.
By their numbers in this assay, from the lowest: compounds 3 and 1 (each within the scatter of the next); then compound 2.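

On a thiocarbonyl carbon, 3-methylpiperidin-1-yl in place of morpholin-4-yl gives a 7.4-fold lower number from compound 2 to compound 3 (0.87 log units; beyond the scatter) in this assay and shows that a change at this position alone can move the number beyond the scatter. The step removes the ring oxygen and adds a methyl group together, so it cannot assign the shift to either change. No measurement at hand accounts for the shift. Open, as far as these compounds go, is where unsubstituted piperidin-1-yl would fall, since it would separate those two changes. Also open, from the compounds shown here alone, is whether moving the methyl group around the piperidine ring alters the number.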